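Lengthening the Ether Chain from Compound 2 to Compound 3

The source may hold more compounds than are shown below. What is called first, only, known or untested is meant among the compounds shown, and "the series" means these compounds.

Compound 1 `CCCOc1ccc2ccc(=O)oc2c1CCC(C)C`: 5600 nM
Compound 2 `CCCCOc1ccc2ccc(=O)oc2c1CCC(C)C`: 16000 nM

In a functional assay on V79 cells (Cricetulus griseus) for cytotoxicity (on this read-out lower numbers stand for stronger inhibition and higher numbers for weaker inhibition), compound 2 gives the higher of the two numbers; the step of a 2.9-fold higher number from compound 1 to compound 2 (0.46 log units; beyond the scatter) is beyond the scatter. Compound 3 `CCCCCCCOc1ccc2ccc(=O)oc2c1CCC(C)C` extends the same chain further: propyl in place of hydrogen on a saturated chain carbon, four bonds along the chain from an oxygen on an aromatic ring. Within the data shown here, the only bearing step is that from compound 1 to compound 2, which was modest; with a longer extension the expected change is a further rise, estimated at a 2.5-fold higher number from compound 2 to compound 3 (0.40 log units; beyond the scatter). Compound 3 is therefore expected to give about 40000 nM in this assay, within a range of 12000 nM to 150000 nM.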

Compound 3, half-maximal inhibitory concentration: 17000 nM
For compound 3 the middle estimate is 2.4-fold (0.37 log units) above the measured one, and the stated range covers the measured number.
By their numbers in this assay, from the lowest: compound 1; then compounds 2 and 3 (each within the scatter of the next).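

In this assay, propyl in place of hydrogen, four bonds along the chain from an oxygen on an aromatic ring, gave a 1.1-fold higher number from compound 2 to compound 3 (0.03 log units; within the scatter), so the further extension left the number unchanged within the scatter. Butyl in place of hydrogen, three bonds along the chain, gave a 3.0-fold higher number from compound 1 to compound 3 (0.48 log units; beyond the scatter), so among these three compounds the only difference beyond the scatter separates compound 1 from the other two. Nothing available explains this flat stretch. As far as these compounds go, whether a still longer chain, or an amine or a carboxylic acid at the chain end, would shift the number remains open.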